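Lengthening the Side Chain: From Amine to Hydroxypropyl

This account rests on a few compounds, and the source may have more. Where it says the series, first, only, none or still open, it means among the compounds named here.

Measured compounds:
- compound 1, `COc1cc(CCCN(C)C)ccc1-c1ccc(C(=O)NS(=O)(=O)c2ccc(NCCSc3ccccc3)c([N+](=O)[O-])c2)cc1`: 1230 nM
- compound 2, `COc1cc(CCC(=O)N(C)C)ccc1-c1ccc(C(=O)NS(=O)(=O)c2ccc(NCCSc3ccccc3)c([N+](=O)[O-])c2)cc1`: 400 nM
- compound 3, `COc1cc(CN(C)C)ccc1-c1ccc(C(=O)NS(=O)(=O)c2ccc(NCCSc3ccccc3)c([N+](=O)[O-])c2)cc1`: 4570 nM

All three share one core and differ only in the side chain carried on a saturated chain carbon bound to an aromatic carbon. In an assay on isolated protein for binding affinity to Apoptosis regulator Bcl-2 (Homo sapiens), read by fluorescence polarization (on this read-out lower numbers stand for stronger inhibition and higher numbers for weaker inhibition), compound 3 gives the highest number of the three, so it is the weakest binder here: the step of a 3.7-fold higher number from compound 1 to compound 3 (0.57 log units; beyond the scatter) and the step of an 11-fold higher number from compound 2 to compound 3 (1.06 log units; beyond the scatter) both run against it, beyond the scatter.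

Compound 4, `COc1cc(CCCO)ccc1-c1ccc(C(=O)NS(=O)(=O)c2ccc(NCCSc3ccccc3)c([N+](=O)[O-])c2)cc1`, has not yet been measured. It arises from compound 3 by the change (2-hydroxyethyl in place of dimethylamino on a saturated chain carbon bound to an aromatic carbon). Among the compounds with values here, two measured steps bear on this. The step of a 3.7-fold higher number from compound 1 to compound 3 (0.57 log units; beyond the scatter) shows that shortening the chain from three carbons to one cost binding, so restoring a three-carbon chain, as compound 4 does, is expected to recover much of that loss. Within the data shown here, the step of a 3.1-fold lower number from compound 1 to compound 2 (0.49 log units; beyond the scatter) shows that a neutral end group on that chain gave a lower number than a basic one; compound 4 also carries a neutral end group, though with a hydrogen-bond donor that no measured compound has. The number for compound 4 is therefore expected to fall between those of compound 1 and compound 2, a step of a 5.7-fold lower number from compound 3 to compound 4 (0.76 log units; beyond the scatter) in this assay. The estimate for compound 4 is 800 nM, with a range from 300 nM to 2500 nM.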

Compound 4, inhibition constant: 721 nM
Beside the measured number, compound 4's estimate is 1.1-fold (0.05 log units) above it; measured number inside the range.
By their numbers in this assay, from the lowest: compounds 2, 4 and 1 (each within the scatter of the next, the first and the last beyond it); then compound 3.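

In this assay, replacing the short (dimethylamino)methyl side chain of compound 3 with 3-hydroxypropyl brings a clear gain, beyond the scatter (a 6.3-fold lower number from compound 3 to compound 4 (0.80 log units; beyond the scatter)). On the longer chain, the end group matters less than this comparison might suggest: hydroxy in place of dimethylamino gives a step within the scatter (a 1.7-fold lower number from compound 1 to compound 4 (0.23 log units; within the scatter)), and so does hydroxymethyl in place of dimethylcarbamoyl (a 1.8-fold higher number from compound 2 to compound 4 (0.26 log units; within the scatter)), so compound 4 cannot be told apart from either neighbour, even though compound 1 and compound 2 differ from each other beyond the scatter. The result also adds a hydrogen-bond donor to this series, and at this position it brings no loss beyond the scatter, though nothing available explains these numbers.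

The change from compound 3 to compound 4 alters both the chain length and its end group, so these compounds cannot show how much of the gain belongs to each; a hydroxymethyl side chain would pair the short length with a hydroxy end. Also open, from the compounds shown here alone, is how far the tolerance on the chain extends, for example to a carboxylic acid at its end or to a longer chain such as 4-hydroxybutyl.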